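Amide series: removing trifluoromethyl from compound 2

The source may report more compounds than this note shows. Statements on the series, on what has been measured and on what is new or still open speak of the compounds shown alone.

Compound 1 `O=C(Nc1cccc(-n2cc(-c3ccncc3)c(-c3ccc(Cl)c(O)c3)n2)c1)Nc1ccc(Cl)c(Cl)c1` gives 6050 nM in a functional assay on MDA-MB-435 cells (Homo sapiens) for inhibition, read by sulforhodamine B assay, with a stated time of 48 h; on this read-out higher numbers stand for weaker inhibition of growth and lower numbers for stronger inhibition of growth. Compound 3 `O=C(Nc1cccc(-n2cc(-c3ccncc3)c(-c3ccc(Cl)c(O)c3)n2)c1)Nc1cc(C(F)(F)F)cc(C(F)(F)F)c1` gives 2590 nM in this assay. Compound 2 `COc1cc(-c2nn(-c3cccc(NC(=O)c4cccc(C(F)(F)F)c4)c3)cc2-c2ccncc2)ccc1Cl` gives 1770 nM in this assay, the lowest of the three numbers shown, with compound 3 within the scatter of it and compound 1 beyond it. Compound 4 `COc1cc(-c2nn(-c3cccc(NC(=O)c4ccccc4)c3)cc2-c2ccncc2)ccc1Cl` differs from compound 2 by one change: hydrogen in place of trifluoromethyl on an aromatic carbon. Among the measured compounds shown here, no measured pair shows this change, so its effect cannot be read from the data. A small step toward weaker growth inhibition is expected, of a size near the edge of the scatter, a 2.0-fold higher number from compound 2 to compound 4 (0.30 log units; within the scatter). Compound 4 is therefore estimated at 3500 nM in this assay, with a range from 1200 nM to 10000 nM.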

Compound 4, concentration for total growth inhibition: 551 nM
Compound 4: the middle estimate sits 6.4-fold (0.80 log units) above what was measured, and the stated range ends above it.
By their numbers in this assay, from the lowest: compound 4; then compounds 2 and 3 (each within the scatter of the next); then compound 1.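

In this assay, among the compounds shown here, this is the first reading of this position, and dropping the group does not cost growth inhibition: the change to hydrogen gives a 3.2-fold lower number from compound 2 to compound 4 (0.51 log units; beyond the scatter) and lies beyond the scatter. For this amide pair, then, 3-(trifluoromethyl)phenyl is not required, and plain benzoyl gives the lower number. Nothing in hand bears on the reason for this step.

As far as these compounds go, whether other groups on this aromatic carbon, such as an amine or a carboxylic acid, would keep the lower number remains open. So does whether the same change would act alike in a compound with a different linker, such as the urea of compound 1.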